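The source may hold more compounds than are shown below. What is called first, only, known or untested is meant among the compounds shown, and "the series" means these compounds.

Compounds measured so far:

- Compound 2 `Cc1ccc([C@@]2(CO)NC[C@H](O)[C@H]2O)cc1` gives 17000 nM in an assay on isolated protein for inhibition of lysosomal alpha-glucosidase (Rattus norvegicus), read by colorimetric assay; a higher number here means a weaker inhibitor, a lower number a stronger inhibitor
- Compound 1 `COc1ccc([C@]2(CO)NC[C@@H](O)[C@@H]2O)cc1` gives 395000 nM in this assay

Compound 2 gives the lowest of the two numbers, and compound 1 sits a long way above it. Compound 3 `Cc1ccc([C@]2(CO)NC[C@@H](O)[C@@H]2O)cc1` is the unmeasured partner of compound 2: the two compounds have the same atoms and bonds and differ only in configuration as drawn: 3 of 3 stereo elements differ (all stereocentres are inverted: mirror images); a stereocentre at a saturated ring carbon is drawn S in compound 2 and R in compound 3; a stereocentre at a saturated ring carbon is drawn S in compound 2 and R in compound 3; a stereocentre at a saturated ring carbon is drawn S in compound 2 and R in compound 3. Going by the values given here, no measured pair of mirror images exists here, so the size of this step is open, but such pairs often differ widely. Compound 3 is expected to be weaker, with a step of an 8.8-fold higher number from compound 2 to compound 3 (0.95 log units; beyond the scatter). The estimate for compound 3 is 150000 nM, within 30000 nM to 800000 nM.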

Compound 3, half-maximal inhibitory concentration: 43000 nM
Estimate against measurement, compound 3: 3.5-fold (0.54 log units) above; the measured number falls inside the stated range.
By their numbers in this assay, from the lowest: compound 2; then compound 3; then compound 1.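

In this assay, inverting all three stereocentres gives a 2.5-fold higher number from compound 2 to compound 3 (0.40 log units; beyond the scatter), so the mirror-image step is real but modest, and configuration alone accounts for it: the fact that compounds 2 and 3 differ only in the configuration as drawn. With the configuration held, methyl in place of methoxy on an aromatic carbon gives a 9.2-fold lower number from compound 1 to compound 3 (0.96 log units; beyond the scatter), which isolates this change from any change in configuration. Still open, from the compounds shown here alone, is whether the methyl-for-methoxy step keeps its size in the opposite configuration, and how an amine or a carboxylic acid on that aromatic carbon would compare.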